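The source may report more compounds than this note shows. Statements on the series, on what has been measured and on what is new or still open speak of the compounds shown alone.

Measured compounds in a functional assay on NUGC-3 cells (Homo sapiens) for inhibition, read by sulforhodamine B assay, with a stated time of 48 h; a higher number here means a weaker inhibitor of growth, a lower number a stronger inhibitor of growth:
Compound 1 `O=C(Nc1cccc(O)c1)C1c2ccccc2CCN1C(=O)c1ccc(Cl)cc1` gives > 10000 nM, which is a limit of the assay.
Compound 2 `O=C(Nc1ccc(C(F)(F)F)cc1)c1nccc2ccccc12` gives > 10000 nM, which is a limit of the assay.
Compound 3 `O=C(Nc1ccccc1O)C1c2ccccc2CCN1C(=O)c1ccc(Cl)cc1` gives > 10000 nM, which is a limit of the assay.

Compound 2 therefore stands at the upper limit only, with no number behind it, and the same holds for the other two measured compounds. Within the data shown here, the single step between measured compounds that differ in one place is a step that the two limits leave unreadable from compound 1 to compound 3, and its size cannot be read because the limit of > 10000 nM in this assay, at which 3 of the 3 values shown sit, holds both of its ends.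

Compound 4 `O=C(Nc1ccc(O)cc1)c1nccc2ccccc12` differs from compound 2 by hydroxy in place of trifluoromethyl on an aromatic carbon. Among the measured compounds shown here, no measured step bears on this change: the one step on record concerns a hydroxyphenyl on the core of compound 1, not the trifluoromethyl of compound 2, and is itself unreadable. So neither direction nor size can be taken from the measured steps for this assay, and the only anchor is that compound 2 sits at a limit. Compound 4 is accordingly expected to stay near that limit, at an estimated 15000 nM with a range of 5000 nM to 50000 nM, most likely reported again as a limit only. The expected step is a step that the limit leaves unreadable from compound 2 to compound 4, that is, none beyond the scatter.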

Compound 4, concentration for 50% growth inhibition: > 10000 nM
Compound 4 was reported as a limit; the forecaster's own chance of this, stated with the estimate: 75%; the middle value lies beyond the limit too.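

In this assay compound 4 gives > 10000 nM, which is a limit of the assay. No new step can be read for compound 2 and compound 4, because both ends rest on one limit: the limit of > 10000 nM in this assay, at which 4 of the 4 values shown sit.

The compounds shown leave open whether hydroxy and trifluoromethyl differ at all in their effect on growth inhibition in this series.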